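From 3,4-dihydroxyphenyl to 3,4-dinitrophenyl on compound 2

The compounds below may be only part of what the source reports. "The series", "measured", "known", "first", "only" and "open" are said of these compounds alone.

Measured in a functional assay on RS4-11 cells (Homo sapiens) for inhibition, read by CCK-8 assay, with a stated time of 48 h; a higher number here means a weaker inhibitor, a lower number a stronger inhibitor:
compound 1 `Cc1cc(C)cc(NC(=O)NCCNS(=O)(=O)c2ccc(-c3ccccc3Oc3ccc([N+](=O)[O-])c([N+](=O)[O-])c3)s2)c1`: 3600 nM
compound 2 `O=C(NCCNS(=O)(=O)c1ccc(-c2ccccc2Oc2ccc(O)c(O)c2)s1)Nc1cc(Cl)cc(Cl)c1`: 4500 nM

In this assay compound 2 gives 4500 nM, which lies within the usual scatter of compound 1, so these two values do not separate the pair. Compound 3 `O=C(NCCNS(=O)(=O)c1ccc(-c2ccccc2Oc2ccc([N+](=O)[O-])c([N+](=O)[O-])c2)s1)Nc1cc(Cl)cc(Cl)c1` has not yet been measured. It carries 3,4-dinitrophenyl in place of the 3,4-dihydroxyphenyl of compound 2 on an oxygen on an aromatic ring (3,4-dinitrophenyl in place of 3,4-dihydroxyphenyl on an oxygen on an aromatic ring). Among the measured compounds shown here, no measured step between compounds that differ in one place is available to size this change. The nearest guide is compound 1, which also carries 3,4-dinitrophenyl and gives 3600 nM, so no step beyond the scatter is expected in this assay. The expected size is a 1.3-fold lower number from compound 2 to compound 3 (0.11 log units; within the scatter), an estimate that stays within the scatter. Compound 3 is estimated at 3500 nM, with an expected range from 1200 nM to 10000 nM.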

Compound 3, half-maximal inhibitory concentration: 2100 nM
Beside the measured number, compound 3's estimate is 1.7-fold (0.22 log units) above it, within the range that was stated.
By their numbers in this assay, from the lowest: compounds 3, 1 and 2 (each within the scatter of the next, the first and the last beyond it).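

In this assay, 3,4-dinitrophenyl in place of 3,4-dihydroxyphenyl on an oxygen on an aromatic ring gives a 2.1-fold lower number from compound 2 to compound 3 (0.33 log units; beyond the scatter), the first step read at this place, modest in size but beyond the scatter. With 3,4-dinitrophenyl held constant, 3,5-dichlorophenyl in place of 3,5-dimethylphenyl on an amide-type nitrogen gives a 1.7-fold lower number from compound 1 to compound 3 (0.23 log units; within the scatter), which stays within the scatter, so these values do not separate that pair. No measurement shown here gives a cause for either step.

The compounds shown leave open whether both nitro groups are needed, since no ring with a single nitro group appears among them. As far as these compounds go, how a 3,4-dimethoxyphenyl or 3,4-diaminophenyl group on the same oxygen would compare also remains open.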